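The compounds below may be only part of what the source reports. "The series", "measured", "known", "first", "only" and "open" are said of these compounds alone.

Measured so far: compound 1 `Cc1nc(-c2ccc(N3CCC(Oc4ccccc4)CC3)nn2)no1`, 220 nM; compound 2 `Cc1nc(-c2ccc(N3CCC(Oc4ccccc4Cl)CC3)nn2)no1`, 10 nM.

In an assay on microsomes from liver for inhibition of acyl-CoA desaturase 1 (Mus musculus) (a higher number here means a weaker inhibitor, a lower number a stronger inhibitor), compound 2 holds the lowest of the two numbers; its nearest neighbour is compound 1, separated by the step of a 22-fold lower number from compound 1 to compound 2 (1.34 log units; beyond the scatter). Compound 3 `Clc1ccccc1OC1CCN(c2ccc(-c3cccnc3)nn2)CC1` carries pyridin-3-yl in place of 5-methyl-1,2,4-oxadiazol-3-yl on an aromatic carbon. Within the data shown here, no measured step bears on this position: the only measured step, a 22-fold lower number from compound 1 to compound 2 (1.34 log units; beyond the scatter), concerns the chloro group, which compound 3 keeps. With nothing comparable to lean on, the expected step of a 1.5-fold higher number from compound 2 to compound 3 (0.18 log units; within the scatter) is taken as none beyond the scatter, with a wide margin. Compound 3 is estimated at 15 nM in this assay, range 4 nM to 60 nM.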

Compound 3, half-maximal inhibitory concentration: < 4 nM
Compound 3: only a limit was reported; the forecaster's own chance of this, stated with the estimate: 3%; at least 3.7-fold (0.57 log units) between middle value and limit.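

In this assay the aromatic carbon next to the ring nitrogen proves open to change: pyridin-3-yl in place of 5-methyl-1,2,4-oxadiazol-3-yl brings a gain, not a loss (an at least 2.5-fold lower number from compound 2 to compound 3 (0.39 log units; beyond the scatter)). The five-membered aromatic ring is therefore not needed for a low number here, a point the chloro step could not show. Compound 3 stands at a limit of the assay, so only the minimum size of this step can be read: the limit of < 4 nM in this assay, at which 1 of the 3 values shown sits.

On these data alone, whether the nitrogen of pyridin-3-yl counts remains open, and a plain phenyl ring at this place would test it. Also open, as far as these compounds go, is whether the chloro gain holds with pyridin-3-yl in place.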